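Three Measured Compounds and One Still Untested

This account rests on a few compounds, and the source may have more. Where it says the series, first, only, none or still open, it means among the compounds named here.

Compound 1, `CC[C@H](C)[C@H](NC(=O)CN(c1nc(Cl)nc2[nH]cnc12)C1CC1)C(=O)O`, gives 21.4% in a functional assay on the whole organism (Tail, strain ICR) with Mus musculus as the target, in the tail flick test, with a stated time of 120 min, at a dose of 25 umol/kg by the oral route; on this read-out lower numbers stand for a weaker effect and higher numbers for a stronger effect at the one dose given. Compound 2, `NC(=O)C[C@H](NC(=O)CN(c1ncnc2c1ncn2C1CCCCO1)C1CC1)C(=O)OCc1ccccc1`, gives 29.2%. Compound 3, `O=C(O)C[C@H](NC(=O)CN(c1nc(Cl)nc2[nH]cnc12)C1CC1)C(=O)O`, gives 22%.

Among the compounds with values here, compound 2 holds the highest of the three numbers, yet no pair of these values is separated beyond the usual scatter. Compound 4, `CC(C)[C@H](NC(=O)CN(c1ncnc2c1ncn2C1CCCCO1)C1CC1)C(=O)OCc1ccccc1`, differs from compound 2 by isopropyl in place of carbamoylmethyl on a saturated chain carbon bound to an amide-type nitrogen and a carbonyl carbon. Within the data shown here, the only measured step that touches the same place is a number 0.6 percentage points higher from compound 1 to compound 3 (within the scatter), which did not move the result beyond the scatter. On that basis the change to compound 4 is expected to leave the number essentially where it is, a number 2.2 percentage points lower from compound 2 to compound 4 (within the scatter). Compound 4 is therefore estimated at 27%, within a range from 13% to 41% in this assay.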

Compound 4, a percentage reported as activity, at one dose (the size of the read-out at that dose, not a potency): 25.8%
Beside the measured number, compound 4's estimate is 1.2 percentage points above it, and the stated range covers the measured number.
By their numbers in this assay, from the lowest: compounds 1, 3, 4 and 2 (each within the scatter of the next).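

In this assay, replacing carbamoylmethyl with isopropyl gives a number 3.4 percentage points lower from compound 2 to compound 4 (within the scatter): the group that leaves has a hydrogen-bond donor and acceptor, the group that enters has neither, and the number stays within the scatter at this one dose. Within the data shown here, the earlier step at this position stood on the core of compound 1, so this is the first such step on the core of compound 2. Nothing shown bears on why the number holds.

Still open, going by these compounds, is whether an amine or a longer chain at this position would move the number beyond the scatter.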